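The compounds below may be only part of what the source reports. "The series", "measured", "known", "first", "only" and "open" are said of these compounds alone.

Measured compounds:
Compound 1, `CCC1Nc2cccc([C@@H]3C[C@H]3CNC(C)=O)c2O1`, in an assay on NIH3T3 cells with melatonin receptor type 1A (Homo sapiens) as the target (on this read-out higher numbers stand for weaker inhibition and lower numbers for stronger inhibition), gives 0.35 nM.
Compound 2, `CCCC(=O)NC[C@@H]1C[C@H]1c1cccc2c1OC(CCC)N2`, in this assay gives 0.94 nM.

Of these two numbers, compound 2 carries the higher one, and the gap between compound 2 and compound 1 lies beyond the usual scatter of repeated measurements. Going by the values given here, the two compounds differ in more than one place, so no single step can be read from that gap; it shows only that compound 1 sits lower in this assay than compound 2 does.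

Compound 3, `CCCC1Nc2cccc([C@@H]3C[C@H]3CNC(=O)C3CC3)c2O1`, is the compound still to be measured. It is derived from compound 2 by one change: cyclopropyl in place of propyl on a carbonyl carbon. The rest of the molecule, including the core and the substituent that carries the oxazoline-type ring in compound 2, is kept.

Among the compounds with values here, nothing measured so far covers this particular exchange, so the expected step rests on the size of the group and on compound 2 alone. Given that compound 2 gives 0.94 nM, the step from a 1.2-fold lower number from compound 2 to compound 3 (0.07 log units; within the scatter) is expected to be small, without a clear direction, and to stay within the scatter. For compound 3 the estimate in this assay is 0.8 nM, expected to fall between 0.3 nM and 2.5 nM.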

Compound 3, inhibition constant: 0.18 nM
Beside the measured number, compound 3's estimate is 4.4-fold (0.65 log units) above it; measured number outside the range, below it.
By their numbers in this assay, from the lowest: compounds 3 and 1 (each within the scatter of the next); then compound 2.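

Exchanging propyl for cyclopropyl on a carbonyl carbon whose other neighbour is the amide-type nitrogen gives a 5.2-fold lower number from compound 2 to compound 3 (0.72 log units; beyond the scatter) in this assay. Both groups hold the same count of carbon heavy atoms and neither has a hydrogen-bond donor or acceptor, so the read-out at this position responds to the closing of the three-membered ring and not merely to the number of carbons present, a point the earlier gap, spanning more than one place, could not show. The data shown offer no measurement that explains this step.

The compounds shown leave open how other groups on this carbonyl carbon, such as isopropyl, cyclobutyl or a longer chain, would compare with cyclopropyl and propyl, and so whether the ring itself is what matters or a three-membered ring in particular. They also leave open whether the same exchange gives a step of similar size with a different substituent on the core, since this single pair carries a propyl chain there.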